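From 4-acetamidophenyl to (4-aminophenyl)amino on a carbonyl carbon

The source may report more compounds than this note shows. Statements on the series, on what has been measured and on what is new or still open speak of the compounds shown alone.

Compound 1 `COc1cccc(-n2nnc(-c3ccccc3NC(=O)c3ccc(NC(C)=O)cc3)n2)c1`: > 100000 nM, a limit
Compound 2 `COc1cccc(-n2nnc(-c3ccccc3NC(=O)c3ccc(NC(=O)CBr)cc3)n2)c1`: > 100000 nM, a limit
Compound 3 `COc1ccc(NC(=O)Nc2ccccc2-c2nnn(-c3ccc(OC)cc3)n2)cc1`: 52500 nM

In an ADME assay on NCI-H460 cells (Homo sapiens) for cytotoxicity, read by MTT assay, with a stated time of 72 h (on this read-out lower numbers stand for stronger inhibition and higher numbers for weaker inhibition), compound 1 gives only a limit, > 100000 nM. Compound 4 `COc1cccc(-n2nnc(-c3ccccc3NC(=O)Nc3ccc(N)cc3)n2)c1` carries (4-aminophenyl)amino in place of 4-acetamidophenyl on a carbonyl carbon. Within the data shown here, the only measured step that starts from compound 1 is a step that the two limits leave unreadable from compound 1 to compound 2, so it sets no size for this change. Compound 3 also has a nitrogen-linked phenyl group on its carbonyl carbon, and in this assay compound 3 gives a number, 52500 nM. That value is the sole ground for what follows. A modest step toward stronger inhibition is therefore expected, an at least 2.0-fold lower number from compound 1 to compound 4 (0.30 log units; that floor lies within the scatter). The estimate for compound 4 is 50000 nM, with an expected range from 15000 nM to 120000 nM.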

Compound 4, half-maximal inhibitory concentration: > 100000 nM
Compound 4 gave a limit, no number; the forecaster's own chance of this, stated with the estimate: 35%; middle value at least 2.0-fold (0.30 log units) away from the limit.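

In this assay compound 4 gives > 100000 nM, a limit. The steps to compound 4 from compound 1 and compound 2 cannot be read, because all three compounds sit at the same limit: the limit of > 100000 nM in this assay, at which 3 of the 4 values shown sit.

On these data alone, what stays open is the size of the change from 4-acetamidophenyl to (4-aminophenyl)amino on the carbonyl carbon.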